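This account rests on a few compounds, and the source may have more. Where it says the series, first, only, none or still open, it means among the compounds named here.

Three compounds share one core and differ only in the group carried on a sulfur. In a functional assay on HT cells (Homo sapiens) for antiproliferative activity, read by fluorescence, with a stated time of 72 h (a lower number here means a stronger inhibitor of growth, a higher number a weaker inhibitor of growth), compound 1 `CC(C)c1n[nH]c2c(NCc3ccc(-c4ccccn4)cc3)nc(SCCO)nc12` gives 48 nM. Compound 2 `CC(C)c1n[nH]c2c(NCc3ccc(-c4ccccn4)cc3)nc(SCC3CNC(=O)O3)nc12` gives 80 nM in this assay. Compound 3 `CC(C)c1n[nH]c2c(NCc3ccc(-c4ccccn4)cc3)nc(SC3CCCC3O)nc12` gives 567 nM in this assay, the highest number of the three, so it is the weakest inhibitor of growth among them: the step of a 12-fold higher number from compound 1 to compound 3 (1.07 log units; beyond the scatter) and the step of a 7.1-fold higher number from compound 2 to compound 3 (0.85 log units; beyond the scatter) both lie beyond the scatter, while a 1.7-fold higher number from compound 1 to compound 2 (0.22 log units; within the scatter).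

Compound 4 `COCSc1nc(NCc2ccc(-c3ccccn3)cc2)c2[nH]nc(C(C)C)c2n1` is the next step from compound 3. The change is methoxymethyl in place of 2-hydroxycyclopentyl on a sulfur, so the five-membered non-aromatic ring and the hydrogen-bond donor leave, and a short chain with one hydrogen-bond acceptor enters.

Both measured steps that reach compound 3 point the same way: the two compounds carrying a short open chain on the sulfur, compound 1 and compound 2, give lower numbers than compound 3, and those steps were large. Returning to a short chain is therefore expected to lower the number again, though how far a chain lacking a hydrogen-bond donor reaches is not shown by any measured pair. The step of a 5.7-fold lower number from compound 3 to compound 4 (0.75 log units; beyond the scatter) is expected to lie beyond the scatter. Compound 4 is estimated at 100 nM in this assay, with a range from 35 nM to 300 nM.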

Compound 4, concentration for 50% growth inhibition: 340 nM
Estimate against measurement, compound 4: 3.4-fold (0.53 log units) below; the measured number lies above the stated range.
By their numbers in this assay, from the lowest: compounds 1 and 2 (each within the scatter of the next); then compounds 4 and 3 (each within the scatter of the next).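

In this assay, a short open chain on the sulfur does not by itself bring back the low numbers: a 1.7-fold lower number from compound 3 to compound 4 (0.22 log units; within the scatter), so methoxymethyl does no better than 2-hydroxycyclopentyl, even though it has no ring and no hydrogen-bond donor. Compound 4 also stands apart from the other two chain compounds, with a 7.1-fold higher number from compound 1 to compound 4 (0.85 log units; beyond the scatter) and a 4.3-fold higher number from compound 2 to compound 4 (0.63 log units; beyond the scatter), which shows that the identity of the group on the chain matters here, not only whether the group on the sulfur is an open chain or a ring. Nothing available gives a reason for these differences.

The compounds shown leave open whether the hydroxyl of compound 1 is what keeps its number low, or whether the length of its chain also counts, and a 2-methoxyethyl group on the sulfur would help separate the two. Also open, going by these compounds, is how a 2-aminoethyl or a carboxymethyl group on the sulfur would compare with the 2-hydroxyethyl group of compound 1.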